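The compounds below may be only part of what the source reports. "The series", "measured", "known", "first", "only" and "open" are said of these compounds alone.

In a functional assay on SK-MEL-5 cells (Homo sapiens) (on this read-out lower numbers stand for stronger inhibition of growth and higher numbers for weaker inhibition of growth), three compounds built on one shared core have been measured. Compound 1 (`COc1cccc(-c2cc(O)c3c(C)cc(C)nc3n2)c1`) gives 288 nM, compound 2 (`COc1cccc(-c2cc(O)c3cc(C)cnc3n2)c1`) gives 25.7 nM and compound 3 (`COc1cccc(-c2cc(O)c3c(C)ccnc3n2)c1`) gives 22.4 nM. Compound 3 and compound 2 lie within the scatter of each other, so together they form the low end of this small set, with compound 1 well above them.

Compound 4 (`COc1cccc(-c2cc(O)c3cccnc3n2)c1`) follows from compound 3 by one change, (hydrogen in place of methyl on an aromatic carbon). Hydrogen replaces methyl on an aromatic carbon, opposite the ring nitrogen. For the measured compounds named here, only one measured step is of the same kind, a 13-fold lower number from compound 1 to compound 3 (1.11 log units; beyond the scatter). That step removed a different methyl group, so it is a loose guide and its large size need not carry over. Going by the values given here, compound 3 still has a methyl group, as does compound 2 at another place, and no measured compound shows the core without one. The values of compound 2 at 25.7 nM and compound 3 at 22.4 nM suggest that moving the methyl changes little in this assay. A much smaller step is therefore expected here, towards a somewhat higher number and near the edge of the scatter, though a lower number cannot be excluded. The expected change is a 1.8-fold higher number from compound 3 to compound 4 (0.25 log units; within the scatter). For compound 4 the estimate is 40 nM, with an expected range from 12 nM to 150 nM.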

Compound 4, concentration for 50% growth inhibition: 53.7 nM
Beside the measured number, compound 4's estimate is 1.3-fold (0.13 log units) below it; the measured number falls inside the stated range.
By their numbers in this assay, from the lowest: compounds 3 and 2 (each within the scatter of the next); then compound 4; then compound 1.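

Removing the last methyl group from the core has a modest cost in this assay: the steps are a 2.4-fold higher number from compound 3 to compound 4 (0.38 log units; beyond the scatter) and a 2.1-fold higher number from compound 2 to compound 4 (0.32 log units; beyond the scatter). For the compounds shown here, the aromatic carbon opposite the ring nitrogen therefore does better with a methyl group than with hydrogen when that methyl is the only one on the core, and compound 4 shows that the core with no methyl at all gives a higher number than either single-methyl compound, though a lower one than compound 1, which carries two. Hydrogen in place of methyl thus has no single direction in this small set, and what it does depends on the core that receives it: the same change on two cores in this assay, a 13-fold lower number (1.11 log units; beyond the scatter) from compound 1 to compound 3 and a 2.1-fold higher number (0.32 log units; beyond the scatter) from compound 2 to compound 4, 27-fold (1.43 log units) apart, beyond the scatter of two such steps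

The compounds shown leave open how this aromatic carbon would respond to a group other than methyl, such as an ethyl group, a chlorine atom or an amine. Also open, on these data alone, is whether the same pattern would hold if the methoxy group on the shared core gave way to another group, for example a hydroxyl group.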